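A few compounds are considered here, and "the series" means these few. Any claim that something is new, unique, unknown or untested is made for them only; others in the source may bear on it.

In a functional assay on A549 cells (Homo sapiens) for cytotoxicity, read by MTT assay, with a stated time of 72 h (on this read-out higher numbers stand for weaker inhibition and lower numbers for stronger inhibition), compound 2 (`CC1CCN(Cc2ccc3nc(NC(=O)N/N=C/c4c[nH]c5ccccc45)sc3c2)CC1`) gives 3580 nM. Compound 3 (`CCN(CC)Cc1ccc2nc(NC(=O)N/N=C/c3c[nH]c4ccccc34)sc2c1`) gives 3300 nM, and compound 1 (`CN(C)Cc1ccc2nc(NC(=O)N/N=C/c3cn(Cc4ccc(C(C)(C)C)cc4)c4ccccc34)sc2c1`) gives 1850 nM. The gaps from compound 2 to both of these lie within the scatter, so the three compounds form a single group on this assay.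

Compound 4 (`CC1CCN(Cc2ccc3nc(NC(=O)N/N=C/c4cn(Cc5ccc(C(C)(C)C)cc5)c5ccccc45)sc3c2)CC1`) departs from compound 2 in one place: 4-(tert-butyl)benzyl in place of hydrogen on an aromatic nitrogen. In words, 4-(tert-butyl)benzyl stands in place of hydrogen on an aromatic nitrogen.

Going by the values given here, the only measured single change, a 1.1-fold lower number from compound 2 to compound 3 (0.04 log units; within the scatter), puts diethylamino in place of 4-methylpiperidin-1-yl. It lies within the scatter, and it concerns the amine and not the aromatic nitrogen. It therefore suggests only that the amine matters little among these compounds. Among the compounds with values here, no measured pair isolates the new group. The nearest evidence is compound 1, which already carries 4-(tert-butyl)benzyl on that nitrogen together with a different amine and gives 1850 nM. Its value sits within the scatter of compound 2, so no change beyond the scatter is expected, although the value of compound 1 leans the expectation slightly towards a lower number.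

The expected change is a 1.8-fold lower number from compound 2 to compound 4 (0.25 log units; within the scatter). For compound 4 the estimated value is 2000 nM, with an expected range of 900 nM to 4400 nM.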

Compound 4, half-maximal inhibitory concentration: 3710 nM
Compound 4: the middle estimate sits 1.9-fold (0.27 log units) below what was measured; the measured number falls inside the stated range.
By their numbers in this assay, from the lowest: compounds 1, 3, 2 and 4 (each within the scatter of the next).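

In this assay, the exchange of hydrogen for 4-(tert-butyl)benzyl on the aromatic nitrogen is now isolated in a single pair, and it gives a 1.0-fold higher number from compound 2 to compound 4 (0.02 log units; within the scatter), so a group of 11 heavy atoms is accommodated at this position without a change beyond the scatter, at least alongside 4-methylpiperidin-1-yl. With 4-(tert-butyl)benzyl in place, 4-methylpiperidin-1-yl in place of dimethylamino gives a 2.0-fold higher number from compound 1 to compound 4 (0.30 log units; within the scatter), which extends to the substituted nitrogen what a 1.1-fold lower number from compound 2 to compound 3 (0.04 log units; within the scatter) showed for the unsubstituted one: neither amine exchange moves the number beyond the scatter. The data offer no account of why this position and the amine leave the number so little changed.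

On these data alone, it remains open whether a plain benzyl, a methyl or a chain ending in a carboxylic acid on that nitrogen would stay within the same group of values. As far as these compounds go, it is also open whether an amine of another kind, such as morpholine or piperazine, would stay there, and whether any of these exchanges would behave the same way on other cells.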